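The source may report more compounds than this note shows. Statements on the series, on what has been measured and on what is new or still open speak of the compounds shown alone.

Compound 2 `COc1cc(-c2nn(-c3cccc(NC(=O)c4cccc(C(F)(F)F)c4)c3)cc2-c2ccncc2)ccc1Cl` carries an amide between the shared core and the 3-(trifluoromethyl)phenyl group. In a functional assay on TK-10 cells (Homo sapiens) for inhibition, read by sulforhodamine B assay, with a stated time of 48 h (a lower number here means a stronger inhibitor of growth, a higher number a weaker inhibitor of growth), compound 2 reaches only the limit of > 50000 nM, so no number is known for it; it therefore stands at one of the two limits among the three values recorded (the limit of > 50000 nM in this assay, at which 1 of the 3 values shown sits). Compound 1 `COc1cc(-c2nn(-c3cccc(NC(=O)Nc4cc(C(F)(F)F)cc(C(F)(F)F)c4)c3)cc2-c2ccncc2)ccc1Cl`, a urea on the same core, gives 2480 nM in this assay. Compound 3 `O=C(Nc1cccc(-n2cc(-c3ccncc3)c(-c3ccc(Cl)c(O)c3)n2)c1)Nc1ccc(Cl)c(Cl)c1`, also a urea but with a hydroxyl in place of the methoxy and a dichlorophenyl at the far end, sits at the other limit (the limit of > 32500 nM in this assay, at which 1 of the 3 values shown sits). In this assay compound 3 gives only the limit of > 32500 nM.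

Compound 4 `COc1cc(-c2nn(-c3cccc(NC(=O)Nc4cccc(C(F)(F)F)c4)c3)cc2-c2ccncc2)ccc1Cl` is not yet measured. It differs from compound 2 by (3-(trifluoromethyl)phenyl)amino in place of 3-(trifluoromethyl)phenyl on a carbonyl carbon, which turns the amide into a urea. Among the compounds with values here, no measured pair isolates this single change. Within the data shown here, compound 1 shows that a urea on this core can give a measurable number, which is the only guide here; the far ring of compound 4 carries one trifluoromethyl rather than two. The step of an at least 5.5-fold lower number from compound 2 to compound 4 (0.74 log units; beyond the scatter) is expected to run toward stronger inhibition, out of the limit, with wide uncertainty. For compound 4 a value of 9000 nM is estimated, within the range 2000 nM to 45000 nM.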

Compound 4, concentration for total growth inhibition: 19000 nM
Beside the measured number, compound 4's estimate is 2.1-fold (0.32 log units) below it; low and high end bracket the measured number.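

Placing (3-(trifluoromethyl)phenyl)amino in place of 3-(trifluoromethyl)phenyl on a carbonyl carbon gives an at least 2.6-fold lower number from compound 2 to compound 4 (0.42 log units; beyond the scatter) in this assay, so with the far ring kept the same, the urea is the stronger inhibitor of growth. This step is only a minimum, because compound 2 is known only as a limit: the limit of > 50000 nM in this assay, at which 1 of the 4 values shown sits. The urea alone does not account for the whole of the strength seen on this core, as hydrogen in place of trifluoromethyl on an aromatic carbon gives a 7.7-fold higher number from compound 1 to compound 4 (0.88 log units; beyond the scatter), showing that the second trifluoromethyl also matters in this urea series.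

The compounds shown leave open whether the gain depends on the added nitrogen carrying its hydrogen, a question that a urea with a methyl group on that nitrogen, or a carbamate with oxygen in its place, would address. They also leave open whether the trifluoromethyl group itself is needed on the far ring of the urea, or whether a chlorine or a nitrile there would serve as well.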